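Ring size of the amine on the carbonyl

This account rests on a few compounds, and the source may have more. Where it says the series, first, only, none or still open, it means among the compounds named here.

In an assay on HEK293 cells for negative allosteric modulation of metabotropic glutamate receptor 5 (Homo sapiens), read by FLIPR, with a stated time of 1 h (a lower number here means a stronger inhibitor, a higher number a weaker inhibitor), compound 1 `O=C(C1CCC1)N1CCc2nc(C#Cc3ccccc3)sc2C1` gives 370 nM. Compound 2 `CC(C)S(=O)(=O)N1CCc2nc(C#Cc3ccccc3)sc2C1` gives 11 nM in this assay; this is a 34-fold lower number from compound 1 to compound 2 (1.53 log units; beyond the scatter). Compound 3 `O=C(N1CCC(F)CC1)N1CCc2nc(C#Cc3ccccc3)sc2C1` shows in this assay only > 10000 nM, which is a limit of the assay and not a number. Compound 3 therefore stands at the limit of > 10000 nM in this assay, at which 1 of the 3 values shown sits. The move to it was an at least 27-fold higher number from compound 1 to compound 3 (1.43 log units; beyond the scatter), so compound 3 is the weakest of the three measured compounds.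

Compound 4 `O=C(N1CCCC1)N1CCc2nc(C#Cc3ccccc3)sc2C1` differs from compound 3 by pyrrolidin-1-yl in place of 4-fluoropiperidin-1-yl on a carbonyl carbon. Among the measured compounds shown here, of the measured steps only an at least 27-fold higher number from compound 1 to compound 3 (1.43 log units; beyond the scatter) bears on this change, and it concerns the whole amine on the carbonyl carbon, not the ring size alone; no measured pair compares two such amines with each other. The change from compound 3 to compound 4 is therefore expected to give at most a modest step in this assay, toward a lower number if any, with a fair chance that again only a limit is reported. Compound 4 is estimated at 8000 nM, in the range 1500 nM to 30000 nM, an expected step of an at least 1.2-fold lower number from compound 3 to compound 4 (0.09 log units; that floor lies within the scatter).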

Compound 4, half-maximal inhibitory concentration: > 10000 nM
Compound 4: a limit, no number; the forecaster's own chance of this, stated with the estimate: 45%; at least 1.2-fold (0.09 log units) between middle value and limit.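

In this assay compound 4 gives > 10000 nM as a limit of the assay and not a number, and the step from compound 3 cannot be read, so no effect of ring size can be stated. Pyrrolidin-1-yl on the carbonyl carbon gives an at least 27-fold higher number from compound 1 to compound 4 (1.43 log units; beyond the scatter) against cyclobutyl, and the same group gives an at least 900-fold higher number from compound 2 to compound 4 (2.95 log units; beyond the scatter) when its carbonyl replaces isopropylsulfonyl on the amine nitrogen in a ring. The drop seen with compound 3 is therefore not tied to the fluorine or to the six-membered ring, since two different cyclic amines on the carbonyl carbon now sit at the same limit: the limit of > 10000 nM in this assay, at which 2 of the 4 values shown sit.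

Going by these compounds, how far compound 3 and compound 4 lie beyond that limit stays open. On these data alone, whether any amine on this carbonyl carbon keeps activity also stays open, and an open-chain dimethylamino group there would test whether the ring matters at all.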